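The source may hold more compounds than are shown below. What is called first, only, known or untested is meant among the compounds shown, and "the series" means these compounds.

In a toxicity assay on NIH3T3 cells (Mus musculus) for cytotoxicity, read by resazurin assay (a higher number here means that more compound is needed for the effect, a lower number that less compound is needed), compound 2 `COC(=O)c1ccc(NCc2cncn2Cc2cccc(F)c2)cc1-c1ccccc1` gives only a limit, > 1000 nM. Compound 1 `N#Cc1ccc(NCc2cncn2Cc2ccc(-c3ccccc3)cc2N)cc1-c1ccccc1` likewise reaches only a limit in this assay, > 1000 nM. Compound 3 `Cc1cccc(-c2cccc(NCc3cncn3Cc3ccccc3)c2)c1` also stops at a limit, > 1000 nM. All three values thus rest at the limit of > 1000 nM in this assay, at which 3 of the 3 values shown sit, so compound 2 stands together with the other two rather than apart from them. Compound 4 `COC(=O)c1ccc(NCc2cncn2Cc2ccccc2C#N)cc1-c1ccccc1` differs from compound 2 by 2-cyanophenyl in place of 3-fluorophenyl on a saturated chain carbon bound to an aromatic nitrogen. Within the data shown here, no measured step between two compounds is available to guide the expectation for this change. The step that the limit leaves unreadable from compound 2 to compound 4 is therefore expected to be none beyond the scatter, in neither direction. Compound 4 is expected to give about 2000 nM, within a range from 700 nM to 6000 nM, most probably again reported only as a limit.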

Compound 4, half-maximal effective concentration: 25000 nM
Compound 4: the middle estimate sits 13-fold (1.10 log units) below what was measured; measured number outside the range, above it.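

Among these compounds, no step from compound 2 to compound 4 can be read in this assay, because compound 2 has only a limit: the limit of > 1000 nM in this assay, at which 3 of the 4 values shown sit. The compounds shown leave open whether 2-cyanophenyl in place of 3-fluorophenyl changes the reading at all.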